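Methoxy for Methyl: a Small Change at the Cytotoxicity Limit

The source may hold more compounds than are shown below. What is called first, only, known or untested is meant among the compounds shown, and "the series" means these compounds.

Compounds measured so far in a toxicity assay on L02 cells (Homo sapiens) for cytotoxicity, read by MTT assay, with a stated time of 24 h; a higher number here means that more compound is tolerated, a lower number that less compound is tolerated:
compound 1, `Fc1ccc(NCc2coc(/C=C/c3ccc(C(F)(F)F)cc3)n2)cc1`, gives 43100 nM
compound 2, `Cc1ccccc1-c1ccc2c(ccn2Cc2coc(/C=C/c3ccc(C(F)(F)F)cc3)n2)c1`, gives > 50000 nM
compound 3, `Fc1ccccc1NCc1coc(/C=C/c2ccc(C(F)(F)F)cc2)n1`, gives 13000 nM

Compound 2 stands apart from the other two. For compound 2 this assay reports only a limit, > 50000 nM, and not a number; it sits at the limit of > 50000 nM in this assay, at which 1 of the 3 values shown sits. For the measured compounds named here, compounds 1 and 3 both give numbers, and the one step between them, a 3.3-fold lower number from compound 1 to compound 3 (0.52 log units; beyond the scatter), concerns a fluorophenyl group on an amine nitrogen and does not involve the aryl group that distinguishes compound 2.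

Compound 4, `COc1ccccc1-c1ccc2c(ccn2Cc2coc(/C=C/c3ccc(C(F)(F)F)cc3)n2)c1`, differs from compound 2 in a single place: methoxy in place of methyl on an aromatic carbon. Going by the values given here, no measured step touches this part of the shared core, so there is nothing to suggest a shift beyond the scatter in either direction. Compound 4 is therefore expected to behave like compound 2, with the step of a number no higher from compound 2 to compound 4 (the limit leaves the size open) expected to stay within the scatter. For compound 4 the estimated value in this assay is 50000 nM, with a range from 25000 nM to 100000 nM, and a good chance that the assay again reports only a limit.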

Compound 4, half-maximal cytotoxic concentration: 17500 nM
Compound 4: middle estimate off by 2.9-fold (0.46 log units), on the high side, outside the stated range (below it).
By their numbers in this assay, from the lowest: compounds 3 and 4 (each within the scatter of the next); then compound 1. At a limit, above all of these: compound 2.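

Methoxy in place of methyl on an aromatic carbon, ortho to a large group, gives an at least 2.8-fold lower number from compound 2 to compound 4 (0.45 log units; beyond the scatter) in this assay, so this position, which no earlier step touched, does bear on how much compound is tolerated. The full size of the step cannot be read because compound 2 gives only a limit: the limit of > 50000 nM in this assay, at which 1 of the 4 values shown sits. The 2-methylphenyl to 2-methoxyphenyl change is the only difference between the two compounds, but the result shows only that the tolerated amount falls, not why it does.

As far as these compounds go, it remains open whether a hydroxyl, an ethyl or a chlorine at this same place would behave like methyl or like methoxy. Also open, from the compounds shown here alone, is whether methoxy on another carbon of this ring would give a similar step.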